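This account rests on a few compounds, and the source may have more. Where it says the series, first, only, none or still open, it means among the compounds named here.

Of the compounds shown here, two from this series have been tested. Compound 1, `CCC(O)[C@@H](CC)Nc1nc(NCc2ccccn2)c2ncn(C(C)C)c2n1`, gives 27000 nM in a functional assay on CH1 cells (Homo sapiens) for inhibition, read by sulforhodamine B assay, with a stated time of 96 h; a higher number here means a weaker inhibitor of growth, a lower number a stronger inhibitor of growth. Compound 2, `CC[C@H](Nc1nc(NCc2ccccn2)c2ncn(C(C)C)c2n1)C(C)O`, gives 21000 nM in the same assay, which is the lower of the two numbers; the two values lie within the scatter of each other, so neither can be called the stronger growth inhibitor. Among the compounds with values here, the one measured step, a 1.3-fold lower number from compound 1 to compound 2 (0.11 log units; within the scatter), is the only guide available.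

Compound 3, `CCC(O)[C@H](CC)Nc1nc(NCc2ccccn2)c2ncn(C(C)C)c2n1`, has not yet been measured. It differs from compound 2 by methyl in place of hydrogen on a saturated chain carbon, two bonds along the chain from an oxygen on a saturated carbon. This is the reverse of the change seen in the step from compound 1 to compound 2, which stayed within the scatter. On that basis no shift beyond the scatter is expected for compound 3 in this assay, and the step of a 1.2-fold higher number from compound 2 to compound 3 (0.08 log units; within the scatter) is the estimate. Compound 3 is therefore expected to give about 25000 nM, most likely between 12000 nM and 52000 nM.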

Compound 3, concentration for 50% growth inhibition: 33000 nM
For compound 3 the middle estimate is 1.3-fold (0.12 log units) below the measured one; measured number inside the range.
By their numbers in this assay, from the lowest: compounds 2, 1 and 3 (each within the scatter of the next).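

In this assay, methyl in place of hydrogen at this place on the chain gives a 1.6-fold higher number from compound 2 to compound 3 (0.20 log units; within the scatter), so measured directly, this change does not move the number beyond the scatter. The new compound also shows something the earlier pair could not: with the stereocentre at a saturated chain carbon drawn R in compound 1 and S in compound 3, the result is only a 1.2-fold higher number from compound 1 to compound 3 (0.09 log units; within the scatter). That stereo comparison comes with one limit: the fact that one of compounds 1 and 3 is drawn with a defined configuration and the other without, at the place where they differ.

As far as these compounds go, it remains open whether a larger change at this place, such as a longer chain or an amine in place of the hydroxy group, would shift the number beyond the scatter. With all three values this close, the compounds shown do not reveal which parts of this side chain, if any, matter for growth inhibition.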